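Shortening the chain from compound 2 to compound 4

The source may hold more compounds than are shown below. What is called first, only, known or untested is meant among the compounds shown, and "the series" means these compounds.

In a functional assay on MCF7 cells (Homo sapiens) for antiproliferative activity, read by MTT assay, with a stated time of 72 h (on this read-out higher numbers stand for weaker inhibition and lower numbers for stronger inhibition), three compounds have been measured. Compound 1 (`CCCCCCCCNC[C@@H]1OC[C@H](N)[C@@H]1O`) gives 96600 nM, compound 2 (`CCCCCCCCCCCCCCNC[C@@H]1OC[C@H](N)[C@H]1O`) gives 8830 nM and compound 3 (`CCCCCCCCCCCCNC[C@@H]1OC[C@H](N)[C@@H]1O`) gives 1800 nM. Compound 2 therefore stands in the middle of the three, with a lower number than compound 1 and a higher one than compound 3.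

Compound 4 (`CCCCCCCCCCNC[C@@H]1OC[C@H](N)[C@H]1O`) is compound 2 with a shorter chain: hydrogen in place of butyl on a saturated chain carbon, ten or more bonds along the chain from an amine nitrogen. Going by the values given here, only one measured step bears on this change, and it runs the opposite way, with butyl in place of hydrogen: a 54-fold lower number from compound 1 to compound 3 (1.73 log units; beyond the scatter). That step is large, but it lies eight bonds along the chain from an amine nitrogen. Compound 1 and compound 3 also differ from compound 2 and compound 4 in the configuration of the core. Among the compounds with values here, no pair on the core of compound 2 has been measured, so the carry-over is uncertain. A higher number for compound 4 is expected, beyond the scatter, but a smaller move than the reverse of the step from compound 1 to compound 3. The estimated change is a 3.4-fold higher number from compound 2 to compound 4 (0.53 log units; beyond the scatter). For compound 4 the estimated value is 30000 nM, with an expected range of 12000 nM to 90000 nM.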

Compound 4, half-maximal inhibitory concentration: 42700 nM
For compound 4 the middle estimate is 1.4-fold (0.15 log units) below the measured one, within the range that was stated.
By their numbers in this assay, from the lowest: compound 3; then compound 2; then compound 4; then compound 1.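

On the core of compound 2, the butyl change now has a measured size in this assay: a 4.8-fold higher number from compound 2 to compound 4 (0.68 log units; beyond the scatter). The shorter chain gives the higher number on this core too, so the direction seen on the core of compound 1 holds in both pairs, while the size does not carry over unchanged: the same change on two cores in this assay, a 54-fold lower number (1.73 log units; beyond the scatter) from compound 1 to compound 3 and a 4.8-fold lower number (0.68 log units; beyond the scatter) from compound 4 to compound 2, 11-fold (1.05 log units) apart, beyond the scatter of two such steps. The two steps also sit at different places along the chain from an amine nitrogen, so the gap between them cannot be assigned to the core alone.

The compounds shown leave open how the two cores compare at one and the same chain, since every pair that differs only in chain length stays on a single core. They also leave open whether a longer chain on the core of compound 2 would lower the number further or the trend would stop there, and what an amine or a hydroxyl at the far end of the chain would do.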